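The source may hold more compounds than are shown below. What is called first, only, known or untested is meant among the compounds shown, and "the series" means these compounds.

Compound 1 `COc1ccc(/C=C/C(=O)Oc2ccc(C(C)=O)cc2)cc1` and compound 2 `COc1cccc(/C=C/C(=O)OC[C@H]2O[C@@H](Oc3ccc(C(C)=O)cc3)[C@H](O)[C@@H](O)[C@@H]2O)c1` have both been tested in an ADME assay on HepG2 2.2.15 cells (Homo sapiens) for cytotoxicity, read by MTT assay; on this read-out higher numbers stand for lower toxicity in this test and lower numbers for higher toxicity in this test. For compound 1 the result is a limit of the assay, > 3270000 nM. For compound 2 the result is also a limit, > 1510000 nM. Neither compound has an exact number, so compound 2 can't be ranked against compound 1, and it stands only at its limit.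

The next compound is compound 3 `CC(=O)c1ccc(O[C@@H]2O[C@H](COC(=O)c3ccco3)[C@@H](O)[C@H](O)[C@H]2O)cc1`, which carries furan-2-yl in place of 2-(3-methoxyphenyl)ethenyl on a carbonyl carbon. Within the data shown here, no measured pair shows what this swap does, so any expectation has to rest on the two limits alone. Neither compound gives an exact number in this assay, so no step beyond the usual scatter is expected, in either direction, and compound 3 may well return only a limit too. The expected change is small: a step that the limit leaves unreadable from compound 2 to compound 3. For compound 3 the estimated value is 2000000 nM, with an expected range from 800000 nM to 3500000 nM.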

Compound 3, half-maximal cytotoxic concentration: 1170000 nM
Estimate against measurement, compound 3: 1.7-fold (0.23 log units) above; the range from low to high includes it.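

In this assay compound 3 gives 1170000 nM, the first exact number among the compounds shown, so a change on this carbonyl carbon can now be tied to a real value. Compound 2 has a limit and not a number, > 1510000 nM. Furan-2-yl in place of 2-(3-methoxyphenyl)ethenyl gives an at least 1.2-fold lower number from compound 2 to compound 3 (0.11 log units; that floor lies within the scatter), so the smallest step these figures allow cannot be told apart from ordinary repeat-to-repeat variation, even though the real step may be larger.

From the compounds shown here alone, the true size of this step stays open, since only an exact number for compound 2 could fix it, and a single swap cannot show whether the furan ring itself or simply the smaller size of the group matters. Other groups on the same carbonyl carbon, such as a thiophene ring, a plain phenyl ring or a short alkyl chain, would be needed to show how far the number follows the group placed there.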